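Swapping diethylamino for dimethylamino in compound 2

A few compounds are considered here, and "the series" means these few. Any claim that something is new, unique, unknown or untested is made for them only; others in the source may bear on it.

Compound 1 `CCN(CC)c1ccc(-c2ccc(C(C)=O)cc2)nn1` gives 25000 nM in a functional assay on Huh-7 cells (Homo sapiens) for antiproliferative activity, with a stated time of 48 h; on this read-out lower numbers stand for stronger inhibition and higher numbers for weaker inhibition
Compound 2 `CCN(CC)c1ccc(-c2ccc(C(=O)OC)cc2)nn1` gives 90 nM in this assay

Compound 2 holds the lower of the two numbers, so it is the stronger inhibitor of this pair. Going by the values given here, the only measured step is large (a 280-fold lower number from compound 1 to compound 2 (2.44 log units; beyond the scatter)) and comes from methoxy in place of methyl on a carbonyl carbon. Compound 3 `COC(=O)c1ccc(-c2ccc(N(C)C)nn2)cc1` keeps the methoxy and changes another place, with dimethylamino in place of diethylamino on an aromatic carbon. Among the compounds with values here, no measured step touches this amino group, so the size of the earlier step cannot simply be carried over. Within the data shown here, compound 1 (25000 nM) shows only that one change can separate these compounds widely. A modest rise in this assay is therefore expected, and no change beyond the scatter remains possible. The expected step is small to moderate (a 2.0-fold higher number from compound 2 to compound 3 (0.30 log units; within the scatter)). Compound 3 is estimated at 180 nM (40 nM to 1200 nM).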

Compound 3, half-maximal inhibitory concentration: > 25000 nM
Compound 3 ended at the assay's limit; the forecaster's own chance of this, stated with the estimate: 3%; middle value at least 130-fold (2.14 log units) from the limit.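

Until now, only the carbonyl end of these compounds had been seen to matter, but the amino group on the aromatic carbon proves just as sensitive: in this assay, the change to dimethylamino gives an at least 270-fold higher number from compound 2 to compound 3 (2.44 log units; beyond the scatter). The group only goes from the 5 heavy atoms of diethylamino to the 3 of dimethylamino, with the same count of hydrogen-bond donors and acceptors and no net charge, so even a small trim at this position can separate a strong inhibitor from a very weak one. Compound 3 sits at a limit of the assay, so its value is not a number and the full size of the step stays unknown: the limit of > 25000 nM in this assay, at which 1 of the 3 values shown sits.

Going by these compounds, whether a longer chain such as dipropylamino, or a ring amine such as piperidine, would hold or improve on compound 2 stays open. With only two amino groups shown, no trend with chain length can be drawn, and the reason for the step remains unexplained.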